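This account rests on a few compounds, and the source may have more. Where it says the series, first, only, none or still open, it means among the compounds named here.

In a functional assay on HCT-116 cells (Homo sapiens) for antiproliferative activity, with a stated time of 48 h (on this read-out higher numbers stand for weaker inhibition and lower numbers for stronger inhibition), three compounds have been tested so far. Compound 1 (`CC(=O)c1ccc(-c2ccc(N3CCCC3)nn2)cc1`) gives only a limit, > 25000 nM. Compound 2 (`COC(=O)c1cccc(-c2ccc(-n3cccc3)nn2)c1`) also gives only a limit, > 25000 nM. Compound 3 (`CCN(CC)c1ccc(-c2ccc(C#N)cc2)nn1`) likewise gives only a limit, > 25000 nM, so it has no exact number. All the data so far therefore rest on (the limit of > 25000 nM in this assay, at which 3 of the 3 values shown sit).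

Compound 4 (`CCN(CC)c1ccc(-c2ccc(C(C)=O)cc2)nn1`) has acetyl in place of cyano on an aromatic carbon. For the measured compounds named here, no measured pair shows the effect of this swap. Compound 1 also carries acetyl, and its result of > 25000 nM is a limit. The estimated change in this assay, a number no higher from compound 3 to compound 4 (the limit leaves the size open), is expected to stay within the usual scatter, with no clear direction. Compound 4 is estimated at 25000 nM, within an expected range of 8000 nM to 50000 nM.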

Compound 4, half-maximal inhibitory concentration: 6000 nM
Beside the measured number, compound 4's estimate is 4.2-fold (0.62 log units) above it; measured number outside the range, below it.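

In this assay, acetyl in place of cyano on an aromatic carbon gives an at least 4.1-fold lower number from compound 3 to compound 4 (0.61 log units; beyond the scatter). Diethylamino in place of pyrrolidin-1-yl gives an at least 4.1-fold lower number from compound 1 to compound 4 (0.61 log units; beyond the scatter), so among these compounds neither acetyl alone, as in compound 1, nor diethylamino alone, as in compound 3, is enough to bring the number down. Compound 4 is the only one with an exact number, and the others give only a limit: the limit of > 25000 nM in this assay, at which 3 of the 4 values shown sit.

Going by these compounds, both steps start from a limit, so their true size stays open. Also open, on these data alone, is whether a carboxylic acid in place of acetyl, or dimethylamino in place of diethylamino, would keep this activity.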